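Swapping the halogen on the pendant phenyl ring

The source may hold more compounds than are shown below. What is called first, only, known or untested is meant among the compounds shown, and "the series" means these compounds.

Measured compounds:
compound 1, `CCCNC(=O)c1cc(Oc2ccc(NC(=O)c3cc4cccnc4n(-c4ccc(F)cc4)c3=O)cc2)ccn1`: 120 nM
compound 2, `CCCNC(=O)c1cc(Oc2ccc(NC(=O)c3cc4cccnc4n(-c4ccc(Cl)cc4)c3=O)cc2)ccn1`: "not determined" (no result reported)

In a functional assay on NCI-H460 cells (Homo sapiens) for antiproliferative activity, read by MTT assay, with a stated time of 72 h (a higher number here means a weaker inhibitor, a lower number a stronger inhibitor), compound 1 gives 120 nM. Going by the values given here, for compound 2 no number is reported in this assay, so it stands nowhere on the scale and no step between measured compounds can be drawn. Compound 3, `CCCNC(=O)c1cc(Oc2ccc(NC(=O)c3cc4cccnc4n(-c4ccc(Br)cc4)c3=O)cc2)ccn1`, differs from compound 2 by bromo in place of chloro on an aromatic carbon. Among the compounds with values here, with no measured step to lean on, the change is expected to bring no shift beyond the usual scatter, with compound 1 as the only anchor. Compound 3 is estimated at 150 nM in this assay, within 50 nM to 500 nM.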

Compound 3, half-maximal inhibitory concentration: 620 nM
Beside the measured number, compound 3's estimate is 4.1-fold (0.62 log units) below it; the whole stated range lies below it.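

In this assay, the choice of halogen at this position matters: bromo in place of fluoro gives a 5.2-fold higher number from compound 1 to compound 3 (0.71 log units; beyond the scatter), a step larger than the usual scatter. Compound 2 has no number, so the step from chloro to bromo cannot be read. Nothing shown explains the loss of activity.

Open, as far as these compounds go, is where chloro falls relative to fluoro and bromo, and whether the trend would extend to iodo. Also open, from the compounds shown here alone, is how a non-halogen group at this position, such as methoxy or an amine, would compare.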